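Hydrazone series on a shared core: antiproliferation working notes

A few compounds are considered here, and "the series" means these few. Any claim that something is new, unique, unknown or untested is made for them only; others in the source may bear on it.

Notes on a small hydrazone series built on one shared core. Compound 1 (`Cn1c(=O)c(=O)n(C2CCCC2)c2nc(N/N=C/c3cc(C(F)(F)F)c(O)c(C(F)(F)F)c3)ncc21`) carries a substituted phenyl hydrazone, and in a functional assay on PC-3 cells (Homo sapiens) for antiproliferative activity, read by MTT assay (a lower number here means a stronger inhibitor, a higher number a weaker inhibitor), compound 1 gives 17700 nM. Compound 2 (`Cn1c(=O)c(=O)n(C2CCCC2)c2nc(N/N=C/c3cccs3)ncc21`) carries thiophen-2-yl on a carbon with a double bond to nitrogen; in this assay compound 2 gives 75600 nM. Among the compounds with values here, of the two numbers so far, compound 2 stands highest, and its gap to compound 1 lies beyond the usual scatter, so compound 2 is the weaker of the pair.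

Compound 3 (`Cn1c(=O)c(=O)n(C2CCCC2)c2nc(N/N=C/c3cccc([N+](=O)[O-])c3)ncc21`) is the next step from compound 2: 3-nitrophenyl in place of thiophen-2-yl on a carbon with a double bond to nitrogen. Within the data shown here, no pair of measured compounds shows this same change, so the size of the step cannot be read from measured steps. A six-membered aromatic ring in place of the five-membered one is expected to lower the number moderately, because compound 1 with its phenyl-type ring gives 17700 nM. The estimated step is a 2.2-fold lower number from compound 2 to compound 3 (0.33 log units; beyond the scatter), toward a lower number, probably beyond the scatter. For compound 3 the expected value in this assay is 35000 nM, with a range from 10000 nM to 120000 nM.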

Compound 3, half-maximal inhibitory concentration: 20300 nM
The estimate for compound 3 lay 1.7-fold (0.24 log units) above the measured number; the range from low to high includes it.
By their numbers in this assay, from the lowest: compounds 1 and 3 (each within the scatter of the next); then compound 2.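

In this assay, the position on a carbon with a double bond to nitrogen now shows a response to one defined change: 3-nitrophenyl in place of thiophen-2-yl gives a 3.7-fold lower number from compound 2 to compound 3 (0.57 log units; beyond the scatter), a modest step. Compound 3 gives 20300 nM, within the scatter of compound 1 at 17700 nM, so these two differently substituted phenyl groups cannot be ordered, and both stand apart from the thiophen-2-yl of compound 2 by more than the scatter. Nothing available here accounts for the step or for this similarity.

The compounds shown leave open whether the step from thiophen-2-yl belongs to the six-membered aromatic ring as such or to the nitro group it carries, a question that plain phenyl would address. They also leave open how far the value at this position depends on the kind of substituent, as a 3-aminophenyl or 3-carboxyphenyl group in the same place would show, and whether another five-membered aromatic ring such as furan-2-yl would track with thiophen-2-yl.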